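A few compounds are considered here, and "the series" means these few. Any claim that something is new, unique, unknown or untested is made for them only; others in the source may bear on it.

In a functional assay on MDA-MB-231 cells (Homo sapiens) for inhibition, with a stated time of 72 h (on this read-out lower numbers stand for stronger inhibition and higher numbers for weaker inhibition), compound 1 `COc1ccc(NC(=O)Nc2nc(Sc3c[nH]c4ccccc34)cc(N3CCN(c4ccccn4)CC3)n2)cc1` gives 28400 nM. Compound 2 `O=C(Nc1ccccc1)Nc1nc(Nc2ccccc2)cc(Sc2c[nH]c3ccccc23)n1` gives 35900 nM, within the scatter of compound 1, so no order is drawn between the two. Compound 3 `Cc1ccc(NC(=O)Nc2nc(Nc3ccccc3)cc(Sc3c[nH]c4ccccc34)n2)cc1` gives 13400 nM, the lowest number of the three and beyond the scatter of both. Compound 1 therefore stands in the upper part of this set, level with compound 2.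

Compound 4 `COc1ccc(NC(=O)Nc2nc(Sc3c[nH]c4ccccc34)cc(N3CCCC3)n2)cc1` is still unmeasured. It keeps the core of compound 1 and carries pyrrolidin-1-yl in place of 4-(pyridin-2-yl)piperazin-1-yl on an aromatic carbon.

Going by the values given here, the only measured step, a 2.7-fold lower number from compound 2 to compound 3 (0.43 log units; beyond the scatter), is modest, and it is methyl in place of hydrogen on an aromatic carbon, a different kind of change. Among the compounds with values here, no measured pair isolates the exchange at hand, so the data give no direction for it. The expected step, a 1.3-fold lower number from compound 1 to compound 4 (0.11 log units; within the scatter), is estimated to stay within the scatter. For compound 4 the expected value is 22000 nM, with an estimated range of 9000 nM to 50000 nM.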

Compound 4, half-maximal inhibitory concentration: 13100 nM
For compound 4 the middle estimate is 1.7-fold (0.23 log units) above the measured one, and the stated range covers the measured number.
By their numbers in this assay, from the lowest: compounds 4 and 3 (each within the scatter of the next); then compounds 1 and 2 (each within the scatter of the next).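

In this assay, going by these compounds alone, the exchange of 4-(pyridin-2-yl)piperazin-1-yl for pyrrolidin-1-yl gives the first readable step at this aromatic carbon: a 2.2-fold lower number from compound 1 to compound 4 (0.34 log units; beyond the scatter). On the core of compound 1, the larger group with its six-membered aromatic ring is therefore not needed for the inhibition seen here, and the position accepts a single five-membered non-aromatic ring with a modest gain. Nothing available explains this step.

The exchange changes ring size and removes the pyridine ring at once, so the compounds shown do not separate these two changes. Piperidin-1-yl, morpholin-4-yl or 4-methylpiperazin-1-yl at this carbon would address that question, and dimethylamino would show whether a ring is needed there at all.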